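Amide Nitrogen Substituent Change Against a Flat Baseline

The compounds below may be only part of what the source reports. "The series", "measured", "known", "first", "only" and "open" are said of these compounds alone.

Measured compounds:
Compound 1 `O=C(/C=C/c1coc2cc(O)ccc2c1=O)NCc1ccc(F)cc1`, in a functional assay on A549 cells (Homo sapiens) for inhibition, read by MTT assay, with a stated time of 48 h (a lower number here means a stronger inhibitor, a higher number a weaker inhibitor), compound 1 gives > 100000 nM, a limit of the assay.
Compound 2 `COc1ccc2c(=O)c(/C=C/C(=O)Nc3ccc(Cl)cc3)coc2c1`, compound 2 gives > 100000 nM, a limit of the assay.
Compound 3 `Cc1ccccc1NC(=O)/C=C/c1coc2cc(O)ccc2c1=O`, compound 3 gives > 100000 nM, a limit of the assay.

All three measured compounds therefore sit at the limit of > 100000 nM in this assay, at which 3 of the 3 values shown sit, and none gives a number. Among the compounds with values here, the one step between measured compounds that differ in a single place, a step that the two limits leave unreadable from compound 1 to compound 3, is a change on the amide-type nitrogen. Both of its ends are limits, so its size cannot be read. Compound 2 stands where the other two stand: at the limit, with no value of its own to place it higher or lower than compound 1 or compound 3.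

Compound 4 `COc1ccc2c(=O)c(/C=C/C(=O)NCc3ccccc3F)coc2c1` differs from compound 2 by 2-fluorobenzyl in place of 4-chlorophenyl on an amide-type nitrogen. The measured step that bears on this change, a swap of the group on the amide-type nitrogen, is a step that the two limits leave unreadable from compound 1 to compound 3, and it gives no readable size. No direction beyond the scatter can therefore be expected for a number no higher from compound 2 to compound 4 (the limit leaves the size open), and the most likely outcome is again a limit. Compound 4 is estimated at 100000 nM, with a range from 30000 nM to 300000 nM.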

Compound 4, half-maximal inhibitory concentration: > 100000 nM
Compound 4: only a limit was reported (the forecaster's own chance of this, stated with the estimate: 85%); the middle value lies on the limit itself.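

Within the data shown here, compound 2 and compound 4 both end at a limit of the assay, so the swap on the amide-type nitrogen gives no step that can be read, and the picture stays as it was: the limit of > 100000 nM in this assay, at which 4 of the 4 values shown sit. The compounds shown leave open whether any group on that nitrogen, or any change to the shared core, would give a measurable value at all.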